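Swapping a sulfonamide for a pyrrolidine amide

The compounds below may be only part of what the source reports. "The series", "measured", "known", "first", "only" and "open" are said of these compounds alone.

Compound 1 `Cc1c(F)c(Oc2cccc(N)c2)nc(Oc2cccc(C(=N)N)c2)c1F` carries an amino group on one of its outer rings; in an assay on isolated protein for inhibition of serine protease 1 (Bos taurus) (a higher number here means a weaker inhibitor, a lower number a stronger inhibitor), compound 1 gives > 5000 nM, which is a limit of the assay rather than a number. Compound 2 `Cc1c(F)c(Oc2cccc(C(=N)N)c2)nc(Oc2cccc(C(=O)O)c2)c1F` carries a carboxy group at that position; in this assay compound 2 gives > 5000 nM, again only a limit. For the measured compounds named here, compound 3 `Cc1c(F)c(Oc2cccc(NS(C)(=O)=O)c2)nc(Oc2cccc(C(=N)N)c2)c1F` carries a methanesulfonamido group, and in this assay compound 3 gives 1900 nM, the only real number among the three. The steps of an at least 2.6-fold lower number from compound 1 to compound 3 (0.42 log units; beyond the scatter) and an at least 2.6-fold lower number from compound 2 to compound 3 (0.42 log units; beyond the scatter) both point toward a stronger inhibitor, though their full size stays hidden by the limit of > 5000 nM in this assay, at which 2 of the 3 values shown sit. The step that the two limits leave unreadable from compound 1 to compound 2 cannot be read at all.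

Compound 4 `Cc1c(F)c(Oc2cccc(C(=N)N)c2)nc(Oc2cccc(C(=O)N3CCCC3)c2)c1F` differs from compound 3 by (pyrrolidin-1-yl)carbonyl in place of methanesulfonamido on an aromatic carbon. Going by the values given here, no measured step compares an amide with a sulfonamide here; the nearest is the carboxy to methanesulfonamido change of an at least 2.6-fold lower number from compound 2 to compound 3 (0.42 log units; beyond the scatter), in which no neutral group lacking a donor appears. A modest loss is therefore expected, estimated as a 1.8-fold higher number from compound 3 to compound 4 (0.27 log units; within the scatter), with a real chance that only a limit is reported. Compound 4 is expected to give 3500 nM, within 900 nM to 12000 nM.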

Compound 4, inhibition constant: 2800 nM
The estimate for compound 4 lay 1.3-fold (0.10 log units) above the measured number; the measured number falls inside the stated range.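

In this assay the step of a 1.5-fold higher number from compound 3 to compound 4 (0.17 log units; within the scatter) leaves the two compounds indistinguishable. So at this position, a group with a five-membered ring and 0 hydrogen-bond donors gives a real number, just as methanesulfonamido with 1 hydrogen-bond donor does. The steps of an at least 1.7-fold lower number from compound 2 to compound 4 (0.25 log units; that floor lies within the scatter) and an at least 1.7-fold lower number from compound 1 to compound 4 (0.25 log units; that floor lies within the scatter) show only floors, and their full size cannot be read because each starts from a limit of the assay: the limit of > 5000 nM in this assay, at which 2 of the 4 values shown sit.

The compounds shown leave open whether the pyrrolidine ring itself matters, which a dimethylamide or a plain primary amide at the same place could test. They also leave open whether a piperidine amide or a morpholine amide would shift the number beyond the scatter.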